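Dichlorophenyl variant of compound 1: expected receptor binding

This account rests on a few compounds, and the source may have more. Where it says the series, first, only, none or still open, it means among the compounds named here.

Within the data shown here, compound 1 `CC(=O)Nc1cccc(C2CCN(CCCn3c(-c4ccccc4)nc4ccccc43)CC2)c1` gives 2 nM in an assay for displacement of a labelled ligand from melanin-concentrating hormone receptor 1 (Homo sapiens), read by fluorescence (on this read-out lower numbers stand for stronger inhibition and higher numbers for weaker inhibition), the lowest of the three numbers measured so far. Compound 2 `CC(=O)Nc1cccc(C2CCN(CCCn3c(-c4cccc(C(F)(F)F)c4)nc4ccccc43)CC2)c1` gives 30 nM and compound 3 `CC(=O)Nc1cccc(C2CCN(CCCn3c(-c4ccc(C(C)C)cc4)nc4ccccc43)CC2)c1` gives 60 nM; both steps away from compound 1 are large: a 15-fold higher number from compound 1 to compound 2 (1.18 log units; beyond the scatter) and a 30-fold higher number from compound 1 to compound 3 (1.48 log units; beyond the scatter). Between those two, a 2.0-fold higher number from compound 2 to compound 3 (0.30 log units; within the scatter). Compound 4 `CC(=O)Nc1cccc(C2CCN(CCCn3c(-c4ccc(Cl)cc4Cl)nc4ccccc43)CC2)c1` carries the change (2,4-dichlorophenyl in place of phenyl on an aromatic carbon). The two measured substitutions on the phenyl both bear on this step and each raised the number sharply, so a further large rise, toward weaker inhibition, is expected for compound 4: a 15-fold higher number from compound 1 to compound 4 (1.18 log units; beyond the scatter). The estimate for compound 4 is 30 nM, with a range of 8 nM to 120 nM.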

Compound 4, half-maximal inhibitory concentration: 3 nM
Estimate against measurement, compound 4: 10-fold (1.00 log units) above; the whole stated range lies above it.
By their numbers in this assay, from the lowest: compounds 1 and 4 (each within the scatter of the next); then compounds 2 and 3 (each within the scatter of the next).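

In this assay substitution on this phenyl is not costly in itself: a 1.5-fold higher number from compound 1 to compound 4 (0.18 log units; within the scatter) leaves 2,4-dichlorophenyl level with phenyl. The losses in compound 2 and compound 3 therefore belong to those particular groups and not to substitution as such, with a 10-fold lower number from compound 2 to compound 4 (1.00 log units; beyond the scatter) and a 20-fold lower number from compound 3 to compound 4 (1.30 log units; beyond the scatter) at the same position. No supporting data are available to explain this difference.

Which of the two chlorines carries the result stays open. Also open, from the compounds shown here alone, is how a methoxy group, an amine or a carboxylic acid on this phenyl would read.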